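This account rests on a few compounds, and the source may have more. Where it says the series, first, only, none or still open, it means among the compounds named here.

compound 1 `CCc1ccnc(O[C@@H]2CC[C@@H](C)N(C(=O)c3ccccc3-n3nccn3)C2)c1` — an assay on CHO-K1 cells for displacement of a labelled ligand from Orexin receptor type 2 (Homo sapiens), read by radioligand binding; on this read-out higher numbers stand for weaker inhibition and lower numbers for stronger inhibition: 0.6 nM
compound 2 `COC(=O)c1ccnc(O[C@@H]2CC[C@@H](C)N(C(=O)c3ccccc3-n3nccn3)C2)c1` — this assay: 3.9 nM
compound 3 `Cc1cccc(O[C@@H]2CC[C@@H](C)N(C(=O)c3ccccc3-n3nccn3)C2)n1` — this assay: 7.6 nM

Compound 3 stands at the upper end of these three numbers: the step of a 13-fold higher number from compound 1 to compound 3 (1.10 log units; beyond the scatter) is large, whereas the step of a 1.9-fold higher number from compound 2 to compound 3 (0.29 log units; within the scatter) lies within the scatter. Compound 4 `Cc1cccnc1O[C@@H]1CC[C@@H](C)N(C(=O)c2ccccc2-n2nccn2)C1` differs from compound 3 by 3-methylpyridin-2-yl in place of 6-methylpyridin-2-yl on an oxygen on a saturated carbon; the two have the same atoms, joined differently. For the measured compounds named here, no measured step matches this change. The steps of a 13-fold higher number from compound 1 to compound 3 (1.10 log units; beyond the scatter) and a 1.9-fold higher number from compound 2 to compound 3 (0.29 log units; within the scatter) each exchanged one pyridyl group for another, and their sizes ran from large to within the scatter, so they give only a loose guide. Compound 4 is therefore expected to stay close to compound 3, with no step beyond the scatter, a 1.1-fold lower number from compound 3 to compound 4 (0.04 log units; within the scatter). Compound 4 is estimated at 7 nM, within 2 nM to 25 nM.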

Compound 4, inhibition constant: 621 nM
Estimate against measurement, compound 4: 89-fold (1.95 log units) below; measured number outside the range, above it.
By their numbers in this assay, from the lowest: compound 1; then compounds 2 and 3 (each within the scatter of the next); then compound 4.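

In this assay the exchange of 6-methylpyridin-2-yl for 3-methylpyridin-2-yl, two groups with the same atoms, gives an 82-fold higher number from compound 3 to compound 4 (1.91 log units; beyond the scatter) and so shows that the place of the methyl on the pyridyl group alone can decide the result at this oxygen. Against the other groups the gap is larger still, with a 160-fold higher number from compound 2 to compound 4 (2.20 log units; beyond the scatter) and a 1000-fold higher number from compound 1 to compound 4 (3.01 log units; beyond the scatter) as well, so compound 4 stands apart from all three earlier compounds. Nothing available explains this change. On these data alone, whether an unsubstituted pyridin-2-yl, a 3-chloropyridin-2-yl or a 3-methoxypyridin-2-yl group would stay near compound 3 or near compound 4 remains open.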